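The source may hold more compounds than are shown below. What is called first, only, known or untested is meant among the compounds shown, and "the series" means these compounds.

Measured so far in an assay for inhibition of apolipoprotein B-100 (Homo sapiens), tested at 100 nM; a higher number here means a weaker inhibitor, a lower number a stronger inhibitor: compound 1 `Cc1cccc(C(=O)Nc2ccc3c(c2)CC(NS(=O)(=O)c2cccs2)C3)c1-c1ccc(F)cc1` gives 1.4 nM; compound 2 `Cc1cccc(C(=O)Nc2ccc3c(c2)CC(NS(=O)(=O)c2cccs2)C3)c1-c1ccc(Cl)cc1` gives 3 nM.

Compound 2 stands highest of the two numbers, with compound 1 nearest, a change of a 2.1-fold higher number from compound 1 to compound 2 (0.33 log units; beyond the scatter) for chloro in place of fluoro on an aromatic carbon. Compound 3 `Cc1cccc(C(=O)Nc2ccc3c(c2)CC(CNS(C)(=O)=O)C3)c1-c1ccc(Cl)cc1` differs from compound 2 by (methanesulfonamido)methyl in place of ((thiophen-2-yl)sulfonyl)amino on a saturated ring carbon. Within the data shown here, the single measured step concerns a halogen on an aromatic carbon and offers no guide to a change at the saturated ring carbon, which is untested. A rise in the number beyond the scatter is nonetheless expected, a 5.0-fold higher number from compound 2 to compound 3 (0.70 log units; beyond the scatter). Compound 3 is estimated at 15 nM, range 3 nM to 80 nM.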

Compound 3, half-maximal inhibitory concentration: 16 nM
Compound 3: middle estimate off by 1.1-fold (0.03 log units), on the low side; low and high end bracket the measured number.
By their numbers in this assay, from the lowest: compound 1; then compound 2; then compound 3.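

In this assay, among these compounds, this is the first reading at the saturated ring carbon, and the change there gives a 5.3-fold higher number from compound 2 to compound 3 (0.73 log units; beyond the scatter), so this position is sensitive to what it carries. The change swaps the five-membered aromatic ring for a methyl on the sulfonyl group and also adds a carbon to the link, so the step cannot be assigned to either part alone. Nothing available explains the step.

Which part carries the step stays open. (Methanesulfonamido) directly on the ring carbon, ((thiophen-2-yl)sulfonyl)aminomethyl, or a plain amine there would each test it.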